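The compounds below may be only part of what the source reports. "The series", "measured", "known", "first", "only" and "open" are said of these compounds alone.

Measured so far:
- compound 1, `O=C(O)c1ccc2noc(-c3cccc(C(F)(F)F)c3)c2c1`: 4620 nM
- compound 2, `O=C(O)c1ccc2noc(-c3cccc(Oc4ccccc4)c3)c2c1`: 850 nM

Both compounds were tested in an assay for inhibition of inositol hexakisphosphate kinase 3 (Homo sapiens), read by colorimetric assay, coupled enzyme assay and malachite green, with a stated time of 120 min, in the presence of a further agent that is not named here; a lower number here means a stronger inhibitor, a higher number a weaker inhibitor. Compound 2 gives the lower of the two numbers, and compound 1 the higher; the step of a 5.4-fold lower number from compound 1 to compound 2 (0.74 log units; beyond the scatter) lies beyond the scatter of repeated runs, so compound 2 counts as the stronger inhibitor of this pair.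

Compound 3, `O=C(O)c1ccc2noc(-c3cccc(Oc4ccccn4)c3)c2c1`, has not yet been measured. It differs from compound 2 in one place: pyridin-2-yl in place of phenyl on an oxygen on an aromatic ring. The ring attached to the oxygen thus gains one nitrogen and with it one hydrogen-bond acceptor, while its size stays the same.

Within the data shown here, no measured step in this set exchanges one ring for another on that oxygen. Among the measured compounds shown here, the only step at hand, a 5.4-fold lower number from compound 1 to compound 2 (0.74 log units; beyond the scatter), concerns a different change, the arrival of the whole phenoxy group, and offers no guide to swapping its phenyl for pyridin-2-yl. With nothing to show a direction, the expected step of a 1.2-fold higher number from compound 2 to compound 3 (0.07 log units; within the scatter) is taken as none beyond the scatter. Compound 3 is therefore estimated at 1000 nM, within a range from 350 nM to 3000 nM.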

Compound 3, half-maximal inhibitory concentration: 10900 nM
Estimate against measurement, compound 3: 11-fold (1.04 log units) below, and the stated range ends below it.
By their numbers in this assay, from the lowest: compound 2; then compound 1; then compound 3.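

In this assay, the ring on the oxygen turns out to matter far more than the earlier pair could show: pyridin-2-yl in place of phenyl keeps the ring size and adds one nitrogen, yet it gives a 13-fold higher number from compound 2 to compound 3 (1.11 log units; beyond the scatter) and so shows that this position can respond strongly to a single ring atom. The earlier step of a 5.4-fold lower number from compound 1 to compound 2 (0.74 log units; beyond the scatter) therefore cannot be read as a gain from any ring held on that oxygen, since (pyridin-2-yl)oxy in place of trifluoromethyl gives a 2.4-fold higher number from compound 1 to compound 3 (0.37 log units; beyond the scatter) and the number moves the opposite way. Nothing measured here gives a reason for this loss.

The compounds shown leave open whether the loss goes with a ring nitrogen wherever it stands, which pyridin-3-yl or pyridin-4-yl on the same oxygen would test. Also open, on these data alone, is whether a ring without aromatic character, such as cyclohexyl, on that oxygen, or a chlorine or a methoxy group on the phenyl of compound 2, would keep, improve or lower the inhibition seen with compound 2.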